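Anilide Ring Change: From Compound 2 to Compound 4

The source may report more compounds than this note shows. Statements on the series, on what has been measured and on what is new or still open speak of the compounds shown alone.

Compound 1 `CCOC(=O)C1=C(Nc2ccccc2)S/C(=C\c2ccc(Br)c(O)c2)C1=O`: 39.8%
Compound 2 `CCOC(=O)C1=C(Nc2ccc(OC)cc2)S/C(=C\c2ccc[nH]2)C1=O`: 27.6%
Compound 3 `CCOC(=O)C1=C(Nc2ccc(OC)c(OC)c2)S/C(=C\c2ccc[nH]2)C1=O`: 47.9%

Of the compounds shown here, three sharing one core have been measured in a functional assay on JAR cells (Homo sapiens) for inhibition, read by MTT assay, with a stated time of 72 h, tested at 10 uM; a higher number here means more inhibition at the concentration tested (going by the name of the read-out), a lower number less inhibition. Compound 2 stands lowest of the three, with compound 1 somewhat higher and compound 3 highest. Within the data shown here, the only step between compounds differing in one place, a number 20.3 percentage points higher from compound 2 to compound 3 (beyond the scatter), concerns adding a methoxy group rather than replacing one.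

Compound 4 `CCOC(=O)C1=C(Nc2ccc(F)cc2)S/C(=C\c2ccc[nH]2)C1=O` differs from compound 2 as follows: fluoro in place of methoxy on an aromatic carbon. Among the measured compounds shown here, no measured step exchanges a methoxy for a fluoro, so that step bears on the question only loosely. In this assay the step of a number 2.4 percentage points higher from compound 2 to compound 4 (within the scatter) is therefore expected to be small, most likely within the scatter. Compound 4 is estimated at 30%, with a range from 15% to 48%.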

Compound 4, a percentage reported as inhibition, at one concentration (the size of the read-out at that concentration, not a potency): 61.5%
Compound 4: middle estimate off by 31.5 percentage points, on the low side; the whole stated range lies below it.
By their numbers in this assay, from the lowest: compound 2; then compounds 1 and 3 (each within the scatter of the next); then compound 4.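

In this assay the change from 4-methoxyphenyl to 4-fluorophenyl gives a number 33.9 percentage points higher from compound 2 to compound 4 (beyond the scatter) and so shows that this position, on an aromatic carbon para to a large group, responds strongly to exchanging its substituent. The earlier step, a number 20.3 percentage points higher from compound 2 to compound 3 (beyond the scatter), showed only the effect of adding a methoxy while the existing one stayed in place. Nothing measured here gives a reason for the new step.

The compounds shown leave open whether a chloro, an amine or a carboxylic acid at this position would match fluoro. Going by these compounds, it also remains open whether the same exchange would raise the number for compound 3.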